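Compound 4: a pyrazole amide replaces the pyridine

This account rests on a few compounds, and the source may have more. Where it says the series, first, only, none or still open, it means among the compounds named here.

Measured so far in a physicochemical assay for solubility, read by LC-MS, in phosphate buffer, with a stated time of 24 h, at pH 7.4; on this read-out lower numbers stand for lower solubility and higher numbers for higher solubility:
- compound 1 `Cc1nc(CO)ccc1-c1cnc(NCc2c(F)ccc3c2CCO3)c2cn[nH]c(=O)c12`: 3000 nM
- compound 2 `CC1(C)CC(=O)N(c2cnc(NCc3c(F)ccc4c3CCO4)n3cnnc23)C1`: 57000 nM
- compound 3 `CN(c1ccccc1)c1cnc(NCc2c(F)ccc3c2CCO3)n2cnnc12`: < 2000 nM

In this assay compound 1 gives 3000 nM, the lower of the two actual numbers, and compound 2 gives 57000 nM. Compound 3 gives < 2000 nM, which is a limit of the assay and not a number.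

Compound 4 `CNC(=O)c1cc(-c2cnc(NCc3c(F)ccc4c3CCO4)c3cn[nH]c(=O)c23)n(C)n1` has not yet been measured. It keeps the core of compound 1 and differs on an aromatic carbon: 1-methyl-3-(methylcarbamoyl)-1H-pyrazol-5-yl in place of 6-(hydroxymethyl)-2-methylpyridin-3-yl on an aromatic carbon. One six-membered aromatic ring with 1 hetero atom thus gives way to one five-membered aromatic ring with 2 hetero atoms.

Among the measured compounds shown here, only one measured step bears on this change, and only indirectly: an at least 28-fold lower number from compound 2 to compound 3 (1.45 log units; beyond the scatter). It also exchanges a group on an aromatic carbon, but on a core other than that of compound 1, and it involves neither group in question here. It shows that such an exchange can be large, but it gives no direction for this one. No step beyond the scatter is therefore expected in this assay, though a wide range is kept because of an at least 28-fold lower number from compound 2 to compound 3 (1.45 log units; beyond the scatter).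

Compound 4 may also return only a limit, given (the limit of < 2000 nM in this assay, at which 1 of the 3 values shown sits). The estimated step is a 1.2-fold lower number from compound 1 to compound 4 (0.08 log units; within the scatter). For compound 4 the expected value is 2500 nM, with an expected range of 1000 nM to 12000 nM.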

Compound 4, solubility: 7000 nM
Beside the measured number, compound 4's estimate is 2.8-fold (0.45 log units) below it; low and high end bracket the measured number.
By their numbers in this assay, from the lowest: compound 1; then compound 4; then compound 2. At a limit, below all of these: compound 3.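

In this assay, among the compounds shown here, the exchange on this aromatic carbon gives a 2.3-fold higher number from compound 1 to compound 4 (0.37 log units; beyond the scatter), a modest step and the first one read on the core of compound 1; the only earlier step stood on another core and showed no direction for this change. It shows that this position, para to a large group, can take a five-membered aromatic ring with 2 hetero atoms in place of the six-membered aromatic ring with 1 hetero atom, and that 1-methyl-3-(methylcarbamoyl)-1H-pyrazol-5-yl goes with the higher number of the two. Nothing measured here accounts for the step, so it stands as an observation without a stated cause.

Because the ring and its substituents all change in this single exchange, the compounds shown do not separate the part played by the five-membered aromatic ring from that of the methylcarbamoyl group. Also open, from the compounds shown here alone, is how a carboxylic acid or a primary amine in place of the methylcarbamoyl group would read at this position, and whether the same exchange would go the same way on the core of compound 2.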